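Swapping the amide aryl ring: a small expected shift

The source may report more compounds than this note shows. Statements on the series, on what has been measured and on what is new or still open speak of the compounds shown alone.

Of the compounds shown here, two sharing one core have been measured in a functional assay on GTL 16 cells for antiproliferative activity against GTL 16 cell line (Homo sapiens), read by CCK-8 assay, with a stated time of 72 h; on this read-out lower numbers stand for stronger inhibition and higher numbers for weaker inhibition. Compound 1 `O=C(Nc1cccc(-c2oc3cc(-c4ccc(F)cc4)ccc3c(=O)c2O)c1)c1ccc(Cl)cc1` gives 9140 nM. Compound 2 `Cc1cc(C(=O)Nc2cccc(-c3oc4cc(-c5ccc(F)cc5)ccc4c(=O)c3O)c2)ccc1F` gives 12100 nM, the higher of the two numbers, although the step of a 1.3-fold higher number from compound 1 to compound 2 (0.12 log units; within the scatter) lies within the usual scatter, so the two compounds cannot be told apart on this read-out.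

Compound 3 `COc1ccc(C(=O)Nc2cccc(-c3oc4cc(-c5ccc(F)cc5)ccc4c(=O)c3O)c2)c(F)c1` has not been measured yet. It differs from compound 2 in one place: 2-fluoro-4-methoxyphenyl in place of 4-fluoro-3-methylphenyl on a carbonyl carbon. For the measured compounds named here, the only measured step that bears on this change is the one from compound 1 to compound 2, which also exchanged the aryl ring on that same carbonyl carbon and produced nothing beyond the scatter. On this basis the step from compound 2 to compound 3 is expected to be a 1.1-fold lower number from compound 2 to compound 3 (0.04 log units; within the scatter), that is, no shift beyond the scatter in either direction. In this assay compound 3 is therefore estimated at 11000 nM, with a plausible range from 4000 nM to 30000 nM.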

Compound 3, half-maximal inhibitory concentration: 15300 nM
Compound 3: middle estimate off by 1.4-fold (0.14 log units), on the low side; the measured number falls inside the stated range.
By their numbers in this assay, from the lowest: compounds 1, 2 and 3 (each within the scatter of the next).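

In this assay, the aryl ring on the amide carbonyl carbon has now been exchanged once more. The incoming 2-fluoro-4-methoxyphenyl carries a hydrogen-bond acceptor that the outgoing 4-fluoro-3-methylphenyl does not, yet the change gives only a 1.3-fold higher number from compound 2 to compound 3 (0.10 log units; within the scatter). The remaining pair, whose rings have no substituent in common, gives a 1.7-fold higher number from compound 1 to compound 3 (0.22 log units; within the scatter), so the three rings tried at this position cannot be told apart on this read-out, and adding a methoxy group to the ring has shown no measurable consequence here. Nothing available explains why these exchanges leave the read-out within the scatter.

From the compounds shown here alone, all three compounds carry a substituted phenyl ring at this position, so it remains open whether a ring bearing a carboxylic acid or a dimethylamino group, or a longer alkyl chain in place of the ring, would give a number beyond the scatter. Going by these compounds, it is also open whether changes elsewhere, such as replacing the 4-fluorophenyl group on the shared core, would move the number more than these exchanges on the amide carbonyl carbon have.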